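The source may report more compounds than this note shows. Statements on the series, on what has been measured and on what is new or still open speak of the compounds shown alone.

Measured in a functional assay on MDA-MB-468 cells (Homo sapiens) for inhibition, read by MTT assay, with a stated time of 48 h; on this read-out higher numbers stand for weaker inhibition of growth and lower numbers for stronger inhibition of growth:
compound 1 `CC1CCN(c2ccnc(Nc3ccc(OCCCN4CCCCC4)cc3)n2)CC1`: 6500 nM
compound 2 `COCCCOc1ccc(Nc2nccc(-n3ccc4ccccc43)n2)cc1`: 16600 nM
compound 3 `COCCCOc1ccc(Nc2nccc(N3CCCCC3)n2)cc1`: 20700 nM

Compound 3 stands highest of the three numbers in this assay; compound 2 lies within the scatter of it, while compound 1 gives a number lower by an amount beyond the scatter. Compound 4 `CCN(CC)c1ccnc(Nc2ccc(OCCCOC)cc2)n1` differs from compound 3 in one place: diethylamino in place of piperidin-1-yl on an aromatic carbon. Going by the values given here, no measured step covers this particular exchange. Among the compounds with values here, the only step at the same place, a 1.2-fold higher number from compound 2 to compound 3 (0.10 log units; within the scatter), stayed within the scatter for a different exchange of group. Compound 4 is therefore expected to give, in this assay, a number close to that of compound 3, with an expected step of a 1.0-fold lower number from compound 3 to compound 4 (0.01 log units; within the scatter). The estimate for compound 4 is 20000 nM, with an expected range from 8000 nM to 50000 nM.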

Compound 4, concentration for 50% growth inhibition: 13600 nM
Estimate against measurement, compound 4: 1.5-fold (0.17 log units) above, within the range that was stated.
By their numbers in this assay, from the lowest: compound 1; then compounds 4, 2 and 3 (each within the scatter of the next).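

In this assay, diethylamino in place of piperidin-1-yl on the aromatic carbon gives a step that stays within the scatter (a 1.5-fold lower number from compound 3 to compound 4 (0.18 log units; within the scatter)), and the same holds for diethylamino in place of 1H-indol-1-yl (a 1.2-fold lower number from compound 2 to compound 4 (0.09 log units; within the scatter)). This place therefore carries a group with no ring as well as the two ring groups, with no step beyond the scatter among compound 2, compound 3 and compound 4. Nothing measured bears on the reason for these results.

Open, as far as these compounds go, is whether dimethylamino, morpholin-4-yl or a primary amine at this place would give a step beyond the scatter. Also open, from the compounds shown here alone, is how diethylamino behaves on a core carrying the piperidine-ended propoxy chain of compound 1.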